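Swapping the aryl group on a piperazine ring

The source may hold more compounds than are shown below. What is called first, only, known or untested is meant among the compounds shown, and "the series" means these compounds.

Compound 1 `Cn1c(CN2CCN(c3ccc(Cl)cc3F)CC2)nc2ccccc21` and compound 2 `COCCn1c(CN2CCN(c3nc(Cl)ccc3C(F)(F)F)CC2)nc2ccccc21` share a core and have both been tested in an assay on CHO cells with metabotropic glutamate receptor 2 (Homo sapiens) as the target, read by FLIPR; on this read-out lower numbers stand for an effect already at smaller amounts and higher numbers for an effect only at larger amounts of compound. In this assay compound 1 gives 126 nM, and compound 2 gives 158 nM; the two numbers lie within the usual scatter of each other, so neither can be set apart from the other.

Compound 3 `Cn1c(CN2CCN(c3ccc(C#N)cc3)CC2)nc2ccccc21` has not yet been measured. It differs from compound 1 in one place: 4-cyanophenyl in place of 4-chloro-2-fluorophenyl on an amine nitrogen in a ring. Going by the values given here, no measured pair shows what such a swap does here, so the size and direction of the step can only be guessed. The expected step is a 2.0-fold higher number from compound 1 to compound 3 (0.30 log units; within the scatter), a small shift toward higher numbers that may well fall within the scatter. Compound 3 is therefore estimated at 250 nM in this assay, with a plausible range from 60 nM to 1000 nM.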

Compound 3, half-maximal effective concentration: > 12500 nM
Compound 3: only a limit was reported (the forecaster's own chance of this, stated with the estimate: 10%); middle value at least 50-fold (1.69 log units) from the limit.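

Compound 3 gives > 12500 nM in this assay as a limit of the assay and not as a number. Going by these compounds alone, the earlier pair differs in more than one place, so only this new pair can show that the aryl group on this amine nitrogen in a ring is far from interchangeable: 4-cyanophenyl in place of 4-chloro-2-fluorophenyl brings an at least 99-fold higher number from compound 1 to compound 3 (1.99 log units; beyond the scatter) on this read-out. Only a lower bound on this step can be read, and it rests on a single limit: the limit of > 12500 nM in this assay, at which 1 of the 3 values shown sits.

As far as these compounds go, the swap removes the chlorine and the fluorine and adds the nitrile all at once, so which of these changes carries the step stays open. A 4-chlorophenyl or a 2-fluorophenyl group on the same nitrogen would help to separate them.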